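The compounds below may be only part of what the source reports. "The series", "measured", "known", "first", "only" and "open" are said of these compounds alone.

Of the compounds shown here, three with a shared core have been tested in a functional assay on NC-37 cells (Homo sapiens) for cytotoxicity; a lower number here means that less compound is tolerated, a higher number that more compound is tolerated. Compound 1 (`C[C@H]1[C@H](O)[C@@H](CO)O[C@H]1n1cc(F)c(=O)[nH]c1=O`) reads > 100 ug/mL, which is a limit of the assay and not a number. Compound 2 (`C[C@H]1[C@H](O)[C@@H](CO)O[C@H]1n1cc(F)c(N)nc1=O`) gives 0.22 ug/mL. Compound 3 (`C[C@H]1[C@H](O)[C@@H](CO)O[C@H]1n1cc(Cl)c(N)nc1=O`) reads > 100 ug/mL, which is again a limit. The standing of compound 3 is therefore given only by the limit of > 100 ug/mL in this assay, at which 2 of the 3 values shown sit.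

Compound 4 (`C[C@H]1[C@H](O)[C@@H](CO)O[C@H]1n1cc(Br)c(N)nc1=O`) keeps the core of compound 3 and alters a single group: bromo in place of chloro on an aromatic carbon. This is bromo in place of chloro on an aromatic carbon, ortho to an amino group.

Among the measured compounds shown here, one measured step bears on this change, since it involves the same aromatic carbon: an at least 450-fold higher number from compound 2 to compound 3 (2.65 log units; beyond the scatter), with chloro in place of fluoro. For the measured compounds named here, that step was large and beyond the scatter, but it is the only guide, and no measured step starts from chloro. With compound 3 already at its limit, no step beyond the scatter is expected in this assay, and a further report of only a limit is more likely than not. The step expected is a number no higher from compound 3 to compound 4 (the limit leaves the size open). For compound 4 the estimated value is 100 ug/mL, with an expected range from 25 ug/mL to 200 ug/mL.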

Compound 4, half-maximal cytotoxic concentration: > 100 ug/mL
Compound 4 was reported as a limit (the forecaster's own chance of this, stated with the estimate: 65%); the middle value sits exactly at the limit.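

In this assay, bromo in place of fluoro on this aromatic carbon gives an at least 450-fold higher number from compound 2 to compound 4 (2.65 log units; beyond the scatter). The large change seen with chloro is therefore no longer a single case: among the three halogens shown with the amino group on the ring, only the fluoro compound, compound 2, gives a readable number, and it is the one of which little is tolerated. Chloro and bromo cannot be ordered against each other, and the step between compound 3 and compound 4 cannot be read, since both compounds report only the same limit and not a number: the limit of > 100 ug/mL in this assay, at which 3 of the 4 values shown sit.

From the compounds shown here alone, whether the low number belongs to fluoro alone stays open, since a hydrogen, a methyl group or an iodo on this same aromatic carbon would show whether fluoro is the exception or whether the other two halogens are. Also open, going by these compounds, is what real numbers compound 3 and compound 4 would give if tested at higher concentrations, and whether the loss of cytotoxicity seen here on one cell line would hold on other cells.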